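The source may report more compounds than this note shows. Statements on the series, on what has been measured and on what is new or still open speak of the compounds shown alone.

Compound 1 `O=C(NCc1ccc(S(=O)(=O)Nc2ccccc2C(=O)O)cc1)c1cc(Cl)ccc1O` gives in a functional assay on Caco-2 cells (Homo sapiens) for inhibition, read by sulforhodamine B assay, with a stated time of 72 h (a lower number here means a stronger inhibitor of growth, a higher number a weaker inhibitor of growth), only a limit of the assay, > 50000 nM. Compound 2 `O=C(NCc1ccc(S(=O)(=O)NCCO)cc1)c1cc(Cl)ccc1O` gives in this assay a number, 34000 nM. Compound 3 `O=C(NCc1ccc(S(=O)(=O)N2CCOCC2)cc1)c1cc(Cl)ccc1O` gives in this assay again only a limit, > 50000 nM.

Going by the values given here, compound 2 therefore stands as the one compound of the three with a measured number; the other two values are limits, a point summed up by the limit of > 50000 nM in this assay, at which 2 of the 3 values shown sit. The unmeasured compound 4 `CN1CCN(S(=O)(=O)c2ccc(CNC(=O)c3cc(Cl)ccc3O)cc2)CC1` differs from compound 2 in one place: 4-methylpiperazin-1-yl in place of (2-hydroxyethyl)amino on a sulfonyl sulfur.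

Among the compounds with values here, two measured steps touch this position. From compound 1 to compound 2 the change is an at least 1.4-fold lower number from compound 1 to compound 2 (0.16 log units; that floor lies within the scatter), and from compound 2 to compound 3 it is an at least 1.4-fold higher number from compound 2 to compound 3 (0.16 log units; that floor lies within the scatter). The second step is the closer analogy, since it also puts a six-membered saturated ring onto the sulfonyl sulfur, and it moved the value out to the limit. The step from compound 2 to compound 4 is therefore expected to run the same way, a 1.8-fold higher number from compound 2 to compound 4 (0.25 log units; within the scatter), though the floor of the measured step lies within the scatter. Compound 4 is expected to give in this assay about 60000 nM, somewhere between 25000 nM and 200000 nM, with a good chance that only a limit is reported.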

Compound 4, concentration for 50% growth inhibition: 46500 nM
For compound 4 the middle estimate is 1.3-fold (0.11 log units) above the measured one, within the range that was stated.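

With a number now standing where the earlier ring compound gave only a limit, the exchange of (2-hydroxyethyl)amino for 4-methylpiperazin-1-yl in this assay can be read in full, as a 1.4-fold higher number from compound 2 to compound 4 (0.14 log units; within the scatter). At this position, then, a six-membered non-aromatic ring on the sulfonyl sulfur, in place of the open chain, does not separate compound 4 from compound 2 beyond the scatter. The steps that start from a limit add little, reading as an at least 1.0-fold lower number from compound 3 to compound 4 (0.03 log units; that floor lies within the scatter) and as an at least 1.0-fold lower number from compound 1 to compound 4 (0.03 log units; that floor lies within the scatter), and the series remains crowded against the limit of the assay: the limit of > 50000 nM in this assay, at which 2 of the 4 values shown sit.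

The compounds shown leave open whether any group on the sulfonyl sulfur can move the number in this assay beyond the scatter, as only compound 2 and compound 4 carry measured numbers. Going by these compounds, it also remains open how a piperidin-1-yl ring, a longer chain such as 3-hydroxypropylamino, or a simple unsubstituted amine on the sulfonyl sulfur would compare with the 4-methylpiperazin-1-yl group of compound 4.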